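The compounds below may be only part of what the source reports. "The series", "measured", "known", "first", "only" and "open" are said of these compounds alone.

Measured so far in an ADME assay on the whole organism (strain S2) for cytotoxicity, with Drosophila as the target, read by WST assay; on this read-out lower numbers stand for higher toxicity in this test and higher numbers for lower toxicity in this test:
compound 1 `CCCCCC(=O)c1c(O)c(Cl)c(OC)c(Cl)c1O` gives 22500 nM;
compound 2 `CCCCCC(=O)c1c(O)c(Cl)c(O)c(Cl)c1O` gives 102000 nM;
compound 3 `CCCCCC(=O)c1c(O)c(Cl)c(C)c(Cl)c1O` gives 13800 nM.

Among these three, compound 2 stands highest, that is, it is the least toxic of the three in this assay. Its nearest neighbour is compound 1, separated by a 4.5-fold higher number from compound 1 to compound 2 (0.66 log units; beyond the scatter). Its furthest neighbour is compound 3, separated by a 7.4-fold lower number from compound 2 to compound 3 (0.87 log units; beyond the scatter). Compound 1 and compound 3 lie close together, separated only by a 1.6-fold lower number from compound 1 to compound 3 (0.21 log units; within the scatter).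

Compound 4 `CCCC(=O)c1c(O)c(Cl)c(O)c(Cl)c1O` is the next compound to be measured. It differs from compound 2 in one place: hydrogen in place of ethyl on a saturated chain carbon, three bonds along the chain from a carbonyl carbon

None of the three measured steps bears on this change. Every one of them alters a substituent on the aromatic ring, whereas the step from compound 2 to compound 4 shortens the saturated chain and leaves the ring untouched. The data therefore give no guidance on the direction of the step, and the default expectation is a step that stays within the usual scatter, in either direction. Compound 4 is accordingly expected to give about 110000 nM in this assay, with a range from 45000 nM to 270000 nM. That estimate means an expected step of a 1.1-fold higher number from compound 2 to compound 4 (0.03 log units; within the scatter).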

Compound 4, half-maximal cytotoxic concentration: > 100000 nM
Compound 4: only a limit was reported (the forecaster's own chance of this, stated with the estimate: 20%); the middle value lies beyond the limit too.
By their numbers in this assay, from the lowest: compounds 3 and 1 (each within the scatter of the next); then compound 2.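

In this assay, for the compounds shown here, compound 4 gives > 100000 nM, which is a limit of the assay and not a number, so no step from compound 2 to compound 4 can be read. The compounds shown leave open whether the change from pentyl to propyl on the shared core moves the read-out in this assay at all, and in which direction.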